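Carboxy in place of 2-carboxyethenyl, second occurrence

The compounds below may be only part of what the source reports. "The series", "measured", "known", "first", "only" and "open" are said of these compounds alone.

Notes on the series, read in an assay for inhibition of inositol hexakisphosphate kinase 2 (Homo sapiens), read by colorimetric assay, coupled enzyme assay and malachite green, with a stated time of 120 min, in the presence of a further agent that is not named here; on this read-out higher numbers stand for weaker inhibition and lower numbers for stronger inhibition. Compound 1 `O=C(O)/C=C/c1ccc2noc(-c3ccc(Oc4ccccc4)cc3)c2c1` gives 94 nM in this assay. Compound 3 `O=C(O)c1ccc2noc(-c3ccc(Oc4ccccc4)cc3)c2c1` carries the change carboxy in place of 2-carboxyethenyl on an aromatic carbon relative to compound 1; in this assay compound 3 gives 280 nM, and the step is a 3.0-fold higher number from compound 1 to compound 3 (0.47 log units; beyond the scatter). Compound 2 `Cc1cccc(-c2onc3ccc(/C=C/C(=O)O)cc23)c1` gives 290 nM; this value and that of compound 3 lie within the scatter of each other, while the value of compound 1 lies beyond the scatter from that of compound 2. The difference between the core of compound 2 and the core of compound 1 is not broken down here.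

Compound 4 `Cc1cccc(-c2onc3ccc(C(=O)O)cc23)c1` is not yet measured. It differs from compound 2 by carboxy in place of 2-carboxyethenyl on an aromatic carbon, the same change as from compound 1 to compound 3, and the place is described in the same words in both cases. The expected step is a 2.9-fold higher number from compound 2 to compound 4 (0.47 log units; beyond the scatter), which rests on the measured step of a 3.0-fold higher number from compound 1 to compound 3 (0.47 log units; beyond the scatter) and on the value of compound 2 290 nM. For compound 4 the estimate is 850 nM, expected to fall between 400 nM and 1800 nM.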

Compound 4, half-maximal inhibitory concentration: 150 nM
Beside the measured number, compound 4's estimate is 5.7-fold (0.75 log units) above it; the measured number lies below the stated range.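

Carboxy in place of 2-carboxyethenyl on an aromatic carbon gives a 1.9-fold lower number from compound 2 to compound 4 (0.29 log units; within the scatter) in this assay. Set against the earlier step, the same change does not carry over from one core to the other in this assay: the same change on two cores in this assay, a 3.0-fold higher number (0.47 log units; beyond the scatter) from compound 1 to compound 3 and a 1.9-fold lower number (0.29 log units; within the scatter) from compound 2 to compound 4, 5.8-fold (0.76 log units) apart, beyond the scatter of two such steps

This shows that a step measured on the core of compound 1 is no safe guide to the same change on the core of compound 2, but it does not show which part of the difference between the two cores sets the steps apart, and it rests on two pairs only.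

The compounds shown leave open how the two cores respond to other replacements for 2-carboxyethenyl, such as a primary amide or a saturated chain ending in carboxy. They also leave open whether a third core would behave like the pair of compound 1 and compound 3 or like the pair of compound 2 and compound 4.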